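Removing a methyl: expected effect on A549 cytotoxicity

The source may report more compounds than this note shows. Statements on the series, on what has been measured and on what is new or still open speak of the compounds shown alone.

Measured compounds:
compound 1 `COc1ccc2[nH]c(-c3ccc[nH]3)c(C3CC(=O)NC3=O)c2c1`: 4000 nM
compound 2 `Cc1ccc2[nH]c(-n3cccn3)c(C3=C(Br)C(=O)NC3=O)c2c1`: 29000 nM

In a functional assay on A549 cells (Homo sapiens) for cytotoxicity, read by MTT assay, with a stated time of 72 h (on this read-out lower numbers stand for stronger inhibition and higher numbers for weaker inhibition), compound 2 gives 29000 nM, the highest of the two numbers shown. Going by the values given here, the only other compound, compound 1, gives a lower number, 4000 nM, so of the two, compound 2 is the weaker inhibitor of cell growth.

Compound 3 `O=C1NC(=O)C(c2c(-n3cccn3)[nH]c3ccccc23)=C1Br` has not yet been tested in this assay. It differs from compound 2 in one place: hydrogen in place of methyl on an aromatic carbon. The change sits on an aromatic carbon of a six-membered aromatic ring of carbon only, part of a fused system of two rings. Among the compounds with values here, no comparable pair with measurements exists here, so there is no direct guide to the size of this step.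

Compound 2 gives 29000 nM, and nothing measured here speaks for a large effect of this change, so the step of a 1.2-fold lower number from compound 2 to compound 3 (0.06 log units; within the scatter) is expected to stay within the usual scatter. Compound 3 is estimated at 25000 nM, with a likely range of 8000 nM to 80000 nM.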

Compound 3, half-maximal inhibitory concentration: 25000 nM
Compound 3: middle estimate and measured number agree at the digits printed; low and high end bracket the measured number.
By their numbers in this assay, from the lowest: compound 1; then compounds 3 and 2 (each within the scatter of the next).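

In this assay, going by these compounds alone, the only single change that can be read directly gives a 1.2-fold lower number from compound 2 to compound 3 (0.06 log units; within the scatter) as its step. Within the data shown here, this is the first direct look at this position: hydrogen in place of methyl on an aromatic carbon of the six-membered ring leaves compound 2 and compound 3 indistinguishable in this test of cell growth. No measurement shown accounts for this, so the pair shows only that the two numbers match, not what lies behind the match.

As far as these compounds go, whether an amine, a carboxylic acid or a longer chain on this same carbon would also leave the number within the scatter stays open, as a single pair says nothing about other groups. Also open, from the compounds shown here alone, is whether removing the methyl would read the same with a different group elsewhere on the core.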